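This account rests on a few compounds, and the source may have more. Where it says the series, first, only, none or still open, it means among the compounds named here.

Two compounds of the series have been run in a functional assay on SNU-638 cells (Homo sapiens) for cytotoxicity; on this read-out lower numbers stand for stronger inhibition and higher numbers for weaker inhibition. Compound 1 `Cc1ccc(NC2=C(Cl)C(=O)c3ncncc3C2=O)cc1C` gives 990 nM in this assay. Compound 2 `CCOc1ccccc1/N=C1/C(=O)c2cncnc2C(O)=C1Cl` gives 690 nM in this assay. Compound 2 holds the lowest number of the two, though the gap to compound 1 is within the usual scatter, so the two are not distinguished from each other. Compound 3 `Cc1ccccc1/N=C1/C(=O)c2cncnc2C(O)=C1Cl` has not been measured. It differs from compound 2 by methyl in place of ethoxy on an aromatic carbon. No measured pair in the series isolates this change, so no step size can be read from the numbers shown. Because compound 1 at 990 nM and compound 2 at 690 nM sit within the scatter of each other despite differing on the aryl ring, no step beyond the scatter is expected in this assay. Compound 3 is expected to give 800 nM, with a likely range of 300 nM to 2500 nM. That estimate means the step of a 1.2-fold higher number from compound 2 to compound 3 (0.06 log units; within the scatter) is expected to stay within the scatter.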

Compound 3, half-maximal inhibitory concentration: 900 nM
Beside the measured number, compound 3's estimate is 1.1-fold (0.05 log units) below it; low and high end bracket the measured number.
By their numbers in this assay, from the lowest: compounds 2, 3 and 1 (each within the scatter of the next).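

In this assay, this first pair differing in one place gives a 1.3-fold higher number from compound 2 to compound 3 (0.12 log units; within the scatter) for methyl in place of ethoxy on an aromatic carbon, ortho to a large group. At this place, going from three heavy atoms and one hydrogen-bond acceptor to one heavy atom and no acceptor produces no step beyond the scatter, so the ethoxy oxygen and the two further heavy atoms are not shown to be required for this read-out. Nothing available here bears on the reason for the size of this step.

As far as these compounds go, the pair covers only ethoxy and methyl, so it stays open whether this insensitivity extends to other groups at this carbon. An amine, a carboxylic acid or a longer chain such as butoxy could still separate from compound 2 and compound 3.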